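Changing the benzyl aryl group of compound 2

The source may hold more compounds than are shown below. What is called first, only, known or untested is meant among the compounds shown, and "the series" means these compounds.

Three compounds have been measured in a functional assay on Capan-2 cells (Homo sapiens) for inhibition, read by MTT assay, with a stated time of 72 h; on this read-out higher numbers stand for weaker inhibition of growth and lower numbers for stronger inhibition of growth:
compound 1 `O=S(=O)(NCCNCc1cccc2ccccc12)c1cc(C(F)(F)F)cc(C(F)(F)F)c1` — 21000 nM
compound 2 `CC(C)(C)c1ccc(CNCCCNS(=O)(=O)c2cc(C(F)(F)F)cc(C(F)(F)F)c2)cc1` — 2100 nM
compound 3 `O=S(=O)(NCCCCNCc1ccc(Br)cc1)c1cc(C(F)(F)F)cc(C(F)(F)F)c1` — 1900 nM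

Compound 2 stands second highest of these three numbers. Its nearest neighbour is compound 3, whose value lies within the scatter of it; its furthest is compound 1, whose value is higher by a gap beyond the scatter. Compound 4 `O=S(=O)(NCCCNCc1ccc(Cl)c(C(F)(F)F)c1)c1cc(C(F)(F)F)cc(C(F)(F)F)c1` differs from compound 2 by 4-chloro-3-(trifluoromethyl)phenyl in place of 4-(tert-butyl)phenyl on a saturated chain carbon bound to an amine nitrogen. Within the data shown here, no pair of measured compounds shows this change, so the expectation rests on compound 2 alone. A step of about a 1.1-fold lower number from compound 2 to compound 4 (0.02 log units; within the scatter) is expected, that is, none beyond the scatter in either direction. Compound 4 is therefore estimated at 2000 nM, with a range from 700 nM to 6000 nM.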

Compound 4, concentration for 50% growth inhibition: 9100 nM
Compound 4: middle estimate off by 4.6-fold (0.66 log units), on the low side; measured number above the stated range.
By their numbers in this assay, from the lowest: compounds 3 and 2 (each within the scatter of the next); then compound 4; then compound 1.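

In this assay, the aryl group on a saturated chain carbon bound to an amine nitrogen proves to matter: 4-chloro-3-(trifluoromethyl)phenyl in place of 4-(tert-butyl)phenyl gives a 4.3-fold higher number from compound 2 to compound 4 (0.64 log units; beyond the scatter) and so weaker inhibition of growth. This is the first step among these compounds that differ in one place, and the earlier values could not show it. Nothing available here accounts for the step. The compounds shown leave open whether 4-chlorophenyl or 3-(trifluoromethyl)phenyl alone would give the same step. Going by these compounds, how plain phenyl or a pyridine ring would read on this carbon also remains open.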